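The source may report more compounds than this note shows. Statements on the series, on what has been measured and on what is new or still open speak of the compounds shown alone.

Compound 1 `O=C(/C=C/CN1CCCCC1)Nc1cc2c(N3CCc4ccccc43)ncnc2cc1O[C@@H]1CCOC1`: 4660 nM
Compound 2 `CN1CCN(C/C=C/C(=O)Nc2cc3c(N4CCc5ccccc54)ncnc3cc2O[C@@H]2CCOC2)CC1`: 6090 nM

Both values come from a functional assay on A549 cells (Homo sapiens) for antiproliferative activity, read by MTT assay, with a stated time of 72 h (a higher number here means a weaker inhibitor, a lower number a stronger inhibitor), and they do not separate: the measured gap is a 1.3-fold higher number from compound 1 to compound 2 (0.12 log units; within the scatter). Compound 1 therefore stands level with compound 2, and neither can be ranked above the other. Compound 3 `O=C(/C=C/CN1CCCCC1)Nc1cc2c(N3CCCc4ccccc43)ncnc2cc1O[C@@H]1CCOC1` is still unmeasured and differs from compound 1 at a single place on the core: 1,2,3,4-tetrahydroquinolin-1-yl in place of 2,3-dihydro-1H-indol-1-yl on an aromatic carbon. This puts 1,2,3,4-tetrahydroquinolin-1-yl in place of 2,3-dihydro-1H-indol-1-yl on an aromatic carbon. Among the compounds with values here, the one measured step lies on a saturated chain carbon, so it is elsewhere in the molecule and bears on this change only indirectly. Within the data shown here, no measured compound varies this group, so no direction can be read from the data, and no step beyond the scatter is expected in this assay. The estimate amounts to an expected 1.0-fold higher number from compound 1 to compound 3 (0.00 log units; within the scatter). For compound 3 the estimated value is 4700 nM, with an expected range of 1600 nM to 14000 nM.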

Compound 3, half-maximal inhibitory concentration: 3670 nM
The estimate for compound 3 lay 1.3-fold (0.11 log units) above the measured number; low and high end bracket the measured number.
By their numbers in this assay, from the lowest: compounds 3, 1 and 2 (each within the scatter of the next).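

In this assay, within the data shown here, the first measured change at this place on the core, 1,2,3,4-tetrahydroquinolin-1-yl in place of 2,3-dihydro-1H-indol-1-yl, gives a 1.3-fold lower number from compound 1 to compound 3 (0.10 log units; within the scatter) and so does not separate the two compounds. On this aromatic carbon, next to the ring nitrogen, the six-membered non-aromatic ring and the five-membered one therefore stand level in this pair, which is as much as a single step can show about the position. Nothing available explains this outcome.

Going by these compounds, it remains open whether a still larger fused ring, such as 2,3,4,5-tetrahydro-1H-1-benzazepin-1-yl, or an open amine such as N-methylanilino, would stand apart from these values at this place. On these data alone, it also remains open whether 1,2,3,4-tetrahydroquinolin-1-yl would give a similar number with 4-methylpiperazin-1-yl or morpholin-4-yl on the chain.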